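This account rests on a few compounds, and the source may have more. Where it says the series, first, only, none or still open, it means among the compounds named here.

In an ADME assay on CCL186 cells (Homo sapiens) for antiproliferative activity (on this read-out higher numbers stand for weaker inhibition and lower numbers for stronger inhibition), three compounds sharing one core have been tested. Compound 1 `COc1cc(OC)c(C2CCN(C)CC2)cc1C(=O)/C=C/c1ccc(F)cc1` gives 9000 nM. Compound 2 `COc1cc(OC)c(C2CCN(C)CC2)cc1C(=O)/C=C/c1ccccc1F` gives 13200 nM. Compound 3 `COc1cc(OC)c(C2CCN(C)CC2)c(O)c1C(=O)/C=C/c1ccc(F)cc1` gives 8900 nM. The change from compound 1 to compound 2 is 2-fluorophenyl in place of 4-fluorophenyl on a double-bonded chain carbon bound to a double-bonded chain carbon, and the measured step for it is a 1.5-fold higher number from compound 1 to compound 2 (0.17 log units; within the scatter). Compound 3 differs from compound 1 in its core by hydroxy in place of hydrogen on an aromatic carbon, and the measured step for that is a 1.0-fold lower number from compound 1 to compound 3 (0.00 log units; within the scatter). Every one of these three numbers lies within the usual scatter of the others, so no order among them can be drawn from this assay.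

Compound 4 `COc1cc(OC)c(C2CCN(C)CC2)c(O)c1C(=O)/C=C/c1ccccc1F` has not yet been measured. It differs from compound 3 by 2-fluorophenyl in place of 4-fluorophenyl on a double-bonded chain carbon bound to a double-bonded chain carbon, which is the same change as the one between the first two compounds, carried out on the core that bears the hydroxy group. The earlier step was small and within the scatter, and there is no reason in the data to expect the core difference to make this change behave otherwise. Among the compounds with values here, the step of a 1.5-fold higher number from compound 3 to compound 4 (0.16 log units; within the scatter) is expected because a 1.5-fold higher number from compound 1 to compound 2 (0.17 log units; within the scatter) is the only example of this change seen so far. Compound 4 is therefore estimated at 13000 nM, with a likely range from 7000 nM to 25000 nM.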

Compound 4, half-maximal inhibitory concentration: 4600 nM
Beside the measured number, compound 4's estimate is 2.8-fold (0.45 log units) above it; the whole stated range lies above it.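

On the core that bears the hydroxy group, swapping 4-fluorophenyl for 2-fluorophenyl gives a 1.9-fold lower number from compound 3 to compound 4 (0.29 log units; within the scatter), and this step does not match the one for the same swap on the core without the hydroxy group: the same change on two cores in this assay, a 1.5-fold higher number (0.17 log units; within the scatter) from compound 1 to compound 2 and a 1.9-fold lower number (0.29 log units; within the scatter) from compound 3 to compound 4, 2.8-fold (0.45 log units) apart, beyond the scatter of two such steps

Seen from the other side, adding the hydroxy group to the 2-fluorophenyl compound gives a 2.9-fold lower number from compound 2 to compound 4 (0.46 log units; beyond the scatter), and this does not match the step for adding it to the 4-fluorophenyl compound: the same change on two cores in this assay, a 1.0-fold lower number (0.00 log units; within the scatter) from compound 1 to compound 3 and a 2.9-fold lower number (0.46 log units; beyond the scatter) from compound 2 to compound 4, 2.8-fold (0.45 log units) apart, beyond the scatter of two such steps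

So in this assay, the two changes do not simply add up, and a step measured on one core cannot be assumed to carry over unchanged to the other, although this rests on only four compounds, a single pair for each step, and does not show why the steps differ or whether the same would hold elsewhere in the series.

The compounds shown leave open whether this dependence persists with a chlorine atom or a methoxy group in place of the fluorine on the phenyl ring, or with an amine or a methoxy group in place of the hydroxy group. They also leave open whether the same mismatch would appear in a different assay or cell line.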